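Removing a chloro group from a weakly active hydrazone

The source may hold more compounds than are shown below. What is called first, only, known or untested is meant among the compounds shown, and "the series" means these compounds.

Of the compounds shown here, two have been measured. Compound 1 `COc1ccc(OC)c(/C=C/c2nnc(Nc3ccc(Cl)cc3)o2)c1` is the more informative one: in a functional assay on SF-268 cells (Homo sapiens) for antiproliferative activity, read by sulforhodamine B assay, with a stated time of 48 h (a lower number here means a stronger inhibitor of growth, a higher number a weaker inhibitor of growth), compound 1 gives 37900 nM. Compound 2 `COc1ccc(OC)c(/C=C/C(=O)N/N=C/c2ccc(Cl)cc2)c1` carries the same dimethoxyphenyl group but joins it through a different linker to the chlorophenyl part. In this assay compound 2 gives > 100000 nM, which is a limit of the assay and not a number. Going by these compounds, compound 2 thus sits at the limit of > 100000 nM in this assay, at which 1 of the 2 values shown sits, so its exact potency is unknown.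

Compound 3 `COc1ccc(OC)c(/C=C/C(=O)N/N=C/c2ccccc2)c1` differs from compound 2 only by hydrogen in place of chloro on an aromatic carbon. Going by the values given here, no measured pair shows the effect of this change here, so the expected step of a number no higher from compound 2 to compound 3 (the limit leaves the size open) is none beyond the scatter, and compound 3 is estimated to remain at or near the limit. Compound 3 is expected at 100000 nM, within the range 40000 nM to 300000 nM.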

Compound 3, concentration for total growth inhibition: > 100000 nM
Compound 3 gave a limit, no number; the forecaster's own chance of this, stated with the estimate: 70%; the middle value lies on the limit itself.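

Compound 2 and compound 3 both stop at a limit of the assay rather than a number, so no step can be read between them: the limit of > 100000 nM in this assay, at which 2 of the 3 values shown sit.

The compounds shown leave open whether going from 4-chlorophenyl to phenyl changes growth inhibition at all in this assay.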